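The compounds below may be only part of what the source reports. "The series", "measured", "known", "first", "only" and "open" are said of these compounds alone.

Working notes on the series.

Three compounds of the shared core have numbers in a functional assay on HEK293 cells for agonist activity at Free fatty acid receptor 1 (Homo sapiens), read by fluorescence and calcium flux, with a stated time of 10 min; on this read-out higher numbers stand for an effect only at larger amounts of compound and lower numbers for an effect already at smaller amounts. Compound 1 `CC#C[C@@H](CC(=O)O)c1ccc(OC[C@H]2COc3ccc(Cl)cc3O2)cc1` gives 50 nM. Compound 2 `CC#C[C@@H](CC(=O)O)c1ccc(OC[C@H]2COc3ccc(F)cc3O2)cc1` gives 210 nM. Compound 3 `CC#C[C@@H](CC(=O)O)c1ccc(OC[C@H]2COc3ccc(OC(F)(F)F)cc3O2)cc1` gives 700 nM, the highest of the three: the step of a 14-fold higher number from compound 1 to compound 3 (1.15 log units; beyond the scatter) is large, and the step of a 3.3-fold higher number from compound 2 to compound 3 (0.52 log units; beyond the scatter) is modest, both beyond the scatter, so every exchange at this aromatic carbon so far has moved the read-out clearly, and the step of a 4.2-fold higher number from compound 1 to compound 2 (0.62 log units; beyond the scatter) shows the same position responding to a smaller change.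

Compound 4 `CC#C[C@@H](CC(=O)O)c1ccc(OC[C@H]2COc3ccc(C(=O)N(C)C)cc3O2)cc1` carries the change (dimethylcarbamoyl in place of trifluoromethoxy on an aromatic carbon). Among the measured compounds shown here, no measured step swaps a halogen or halogenated ether for an amide-type group, so none bears on this change directly; the measured steps only show that this position is sensitive, in either direction by a modest to large amount. For the measured compounds named here, with no precedent for the direction, the expectation for compound 4 is a number near that of compound 3, with a wide range covering a modest step either way, i.e. an expected step of a 1.2-fold lower number from compound 3 to compound 4 (0.07 log units; within the scatter). Compound 4 is therefore estimated at 600 nM, with an expected range from 150 nM to 3000 nM.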

Compound 4, half-maximal effective concentration: > 30000 nM
Compound 4: a limit, no number (the forecaster's own chance of this, stated with the estimate: 5%); at least 50-fold (1.69 log units) between middle value and limit.
By their numbers in this assay, from the lowest: compound 1; then compound 2; then compound 3. At a limit, above all of these: compound 4.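

In this assay compound 4 stands at > 30000 nM, which is a limit of the assay and not a number: the limit of > 30000 nM in this assay, at which 1 of the 4 values shown sits.

Dimethylcarbamoyl gives an at least 42-fold higher number from compound 3 to compound 4 (1.63 log units; beyond the scatter), alongside an at least 140-fold higher number from compound 2 to compound 4 (2.15 log units; beyond the scatter) and an at least 600-fold higher number from compound 1 to compound 4 (2.77 log units; beyond the scatter), all beyond the scatter, so this aromatic carbon accepts changes that go well past the steps among the three earlier compounds. Trifluoromethoxy and dimethylcarbamoyl match in the counts of heavy atoms and hydrogen-bond acceptors, so those counts alone do not separate a measurable compound from one at the limit here.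

As far as these compounds go, it remains open whether the shift belongs to the amide as such or to its two methyl groups, which an unsubstituted carboxamide at this carbon would test. From the compounds shown here alone, how a nitrile, a carboxylic acid or an amine would read at this carbon also remains open.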